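Bromoacrylamide series: benzyl replacing aryl on the fused core

A few compounds are considered here, and "the series" means these few. Any claim that something is new, unique, unknown or untested is made for them only; others in the source may bear on it.

Three compounds of the series have numbers in a functional assay on CCRF-CEM cells (Homo sapiens) for inhibition, read by cell counting, with a stated time of 3 days; on this read-out higher numbers stand for weaker inhibition and lower numbers for stronger inhibition. Compound 1, `Nc1cccc(-c2cn3nc(-c4cccs4)sc3n2)c1`, carries a free amine and a thienyl group on the fused core; in this assay compound 1 gives only a limit, > 250000 nM, and no number. Compound 2, `C=C(Br)C(=O)Nc1cccc(-c2cn3nc(-c4ccc(CC)cc4)sc3n2)c1`, carries the bromoacrylamide and a 4-ethylphenyl group; in this assay compound 2 gives 3400 nM. Compound 3, `COc1ccc(-c2csc3nc(-c4cccc(N)c4)cn23)cc1`, a different fused core with a free amine and a methoxyphenyl group, gives 6100 nM in this assay. Compound 2 has the lower of the two numbers, but the value of compound 3 lies within the usual scatter of it, so the two are not separated. Compound 4, `C=C(Br)C(=O)Nc1cccc(-c2cn3nc(Cc4ccc(OC)cc4)sc3n2)c1`, keeps the bromoacrylamide of compound 2 and differs from it at one place: 4-methoxybenzyl in place of 4-ethylphenyl on an aromatic carbon. Among the compounds with values here, no measured pair isolates this change, so its size is unknown. A modest step is expected, in the direction of weaker inhibition or none beyond the scatter: a 1.6-fold higher number from compound 2 to compound 4 (0.21 log units; within the scatter). For compound 4 in this assay the estimate is 5500 nM, with a range of 1500 nM to 20000 nM.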

Compound 4, half-maximal inhibitory concentration: 2300 nM
Beside the measured number, compound 4's estimate is 2.4-fold (0.38 log units) above it; the range from low to high includes it.
By their numbers in this assay, from the lowest: compounds 4, 2 and 3 (each within the scatter of the next, the first and the last beyond it). At a limit, above all of these: compound 1.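

In this assay, this position, on an aromatic carbon next to the ring nitrogen and next to the ring sulfur, now has a measured step: a 1.5-fold lower number from compound 2 to compound 4 (0.17 log units; within the scatter), within the scatter. A benzyl group carrying a methoxy substituent therefore stands here in place of a directly attached 4-ethylphenyl group with no separation between the two bromoacrylamides, compound 2 and compound 4. Within the data shown here, this is the only one-place comparison, and it shows no loss on this change within the numbers at hand.

From the compounds shown here alone, the step alters the link to the ring and the ring's substituent together, and neither is read alone; an unsubstituted benzyl or a longer chain such as phenethyl at this position remains open. Compound 1 gives only a limit, and no step to it can be read: the limit of > 250000 nM in this assay, at which 1 of the 4 values shown sits.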